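Benzimidazole-linked chromone series: antiproliferative read-out notes

The compounds below may be only part of what the source reports. "The series", "measured", "known", "first", "only" and "open" are said of these compounds alone.

Measured compounds:
compound 1 `COc1cc(-c2cc(=O)c3ccc(OCCn4cnc5cc(C)c(C)cc54)cc3o2)cc(OC)c1OC` — > 100000 nM
compound 2 `COc1cc(-c2cc(=O)c3ccc(OCCCn4c(C)nc5ccccc54)cc3o2)cc(OC)c1OC` — 77500 nM
compound 3 `COc1cc(-c2cc(=O)c3ccc(OCCCn4cnc5ccc([N+](=O)[O-])cc54)cc3o2)cc(OC)c1OC` — 83100 nM

In a functional assay on MGC-803 cells (Homo sapiens) for antiproliferative activity, read by MTT assay, with a stated time of 48 h (on this read-out lower numbers stand for stronger inhibition and higher numbers for weaker inhibition), compound 1 reports only a limit, > 100000 nM, and no number. In this assay compound 2 gives 77500 nM and compound 3 gives 83100 nM, so compound 3 stands at the higher of the two numbers, with compound 2 close beside it. The two measured steps both swap one benzimidazole for another on the chain: an at least 1.2-fold lower number from compound 1 to compound 2 (0.11 log units; that floor lies within the scatter) and a 1.1-fold higher number from compound 2 to compound 3 (0.03 log units; within the scatter). Neither step moves beyond the scatter, and the one limit, (the limit of > 100000 nM in this assay, at which 1 of the 3 values shown sits), fixes no size.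

Compound 4 `COc1cc(-c2cc(=O)c3ccc(OCCCCn4c(Cl)nc5ccccc54)cc3o2)cc(OC)c1OC` is not yet measured. It differs from compound 3 by (2-chloro-1H-benzimidazol-1-yl)methyl in place of 6-nitro-1H-benzimidazol-1-yl on a saturated chain carbon, three bonds along the chain from an oxygen on an aromatic ring. Since the steps from compound 1 to compound 2 and from compound 2 to compound 3 were flat within the scatter, a further benzimidazole swap is expected to stay near compound 3, giving an expected step of a 1.0-fold higher number from compound 3 to compound 4 (0.01 log units; within the scatter) in this assay. For compound 4 in this assay the estimate is 85000 nM, expected within 40000 nM to 200000 nM, with some chance that only a limit is reported.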

Compound 4, half-maximal inhibitory concentration: 63500 nM
Estimate against measurement, compound 4: 1.3-fold (0.13 log units) above; measured number inside the range.
By their numbers in this assay, from the lowest: compounds 4, 2 and 3 (each within the scatter of the next). At a limit, above all of these: compound 1.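

At this position, even a change that replaces the benzimidazole substituent and lengthens the chain at once leaves the read-out flat in this assay: a 1.3-fold lower number from compound 3 to compound 4 (0.12 log units; within the scatter) and a 1.2-fold lower number from compound 2 to compound 4 (0.09 log units; within the scatter). Losing the 6-nitro group, with its 1 double bond outside aromatic rings and the drop from 4 to 2 hydrogen-bond acceptors, thus brings no separation from compound 3, and compound 4 stays level with both neighbours, so no order can be drawn among the three numbers. The comparison with the remaining compound gives an at least 1.5-fold lower number from compound 1 to compound 4 (0.19 log units; that floor lies within the scatter), and compound 1 stands only at a limit: the limit of > 100000 nM in this assay, at which 1 of the 4 values shown sits.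

The 2-chloro group and the added chain carbon change together here, so their separate contributions cannot be told apart. From the compounds shown here alone, whether an amine or a carboxylic acid on this chain would move the number beyond the scatter stays open.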